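The compounds below may be only part of what the source reports. "The series", "measured", "known", "first", "only" and "open" are said of these compounds alone.

Compounds measured so far in an ADME assay on HepG2 cells (Homo sapiens) for cytotoxicity, read by MTT assay, with a stated time of 24 h; on this read-out lower numbers stand for higher toxicity in this test and higher numbers for lower toxicity in this test:
- Compound 1 (`Fc1ccc(-c2cn(-c3ccnc4cc(Cl)ccc34)nn2)cc1`) gives > 3080000 nM as a limit
- Compound 2 (`O=C(OCc1cn(-c2ccnc3cc(Cl)ccc23)nn1)c1ccccc1`) gives > 2740000 nM as a limit
- Compound 3 (`O=C(OCc1cn(-c2ccnc3cc(Cl)ccc23)nn1)c1ccc(C(F)(F)F)cc1`) gives 1070000 nM as a number

Compound 1 stands at a limit of this assay and has no number of its own. Compound 2 is also only a limit, so compound 3 alone carries a true number. The next compound, compound 4 (`CN(C)Cc1cn(-c2ccnc3cc(Cl)ccc23)nn1`), keeps the core of compound 1 and changes one group, with (dimethylamino)methyl in place of 4-fluorophenyl on an aromatic carbon as the counted difference. In words, (dimethylamino)methyl stands in place of 4-fluorophenyl on an aromatic carbon. Within the data shown here, the only measured step, an at least 2.5-fold lower number from compound 2 to compound 3 (0.40 log units; beyond the scatter), is a different change and bears on this one only loosely. It does show that one substitution in this small set can move the read-out beyond the scatter. The estimated change is an at least 2.0-fold lower number from compound 1 to compound 4 (0.31 log units; beyond the scatter) and it is expected to be modest, toward a lower number, although the limit for compound 1 leaves its true size open. The estimate for compound 4 is an expected 1500000 nM with 500000 nM to 4000000 nM as its range.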

Compound 4, half-maximal cytotoxic concentration: 1850000 nM
For compound 4 the middle estimate is 1.2-fold (0.09 log units) below the measured one; the measured number falls inside the stated range.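

In this assay, the aromatic carbon of the five-membered ring with 3 nitrogen accepts (dimethylamino)methyl in place of 4-fluorophenyl, and this swap of a ringed group for an open one with a hydrogen-bond acceptor gives an at least 1.6-fold lower number from compound 1 to compound 4 (0.22 log units; that floor lies within the scatter) and a true number for compound 4. Since that floor lies within the scatter, the step alone does not establish a real drop at this position. As far as these compounds go, its true size stays open because compound 1 stands only at a limit: the limit of > 3080000 nM in this assay, at which 1 of the 4 values shown sits.

The compounds shown leave open whether a different amine here, such as morpholine, a carboxylic acid, or a longer chain ending in dimethylamino would read differently. Also open, from the compounds shown here alone, is how much of the step goes with the lost ring and how much with the entering nitrogen, which a plain propyl chain on this carbon would help to separate.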